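This account rests on a few compounds, and the source may have more. Where it says the series, first, only, none or still open, it means among the compounds named here.

Measured compounds in a functional assay on the whole organism for inhibition, with Mythimna separata as the target, with a stated time of 5 days; on this read-out higher numbers stand for an effect only at larger amounts of compound and lower numbers for an effect already at smaller amounts:
Compound 1 `CC(C)(C)n1ncc(OCc2nnc(-c3ccc(Cl)cc3Cl)s2)c(Cl)c1=O` gives 62.2 ug/mL.
Compound 2 `CC(C)(C)n1ncc(OCc2nnc(-c3cc(F)c(Cl)c([N+](=O)[O-])c3Cl)o2)c(Cl)c1=O` gives only a limit of the assay, > 300 ug/mL.
Compound 3 `CC(C)(C)n1ncc(OCc2nnc(-c3cccs3)o2)c(Cl)c1=O` gives only a limit of the assay, > 300 ug/mL.

Compound 3 stands at the limit of > 300 ug/mL in this assay, at which 2 of the 3 values shown sit, so its result is a limit and not a number, and it cannot be placed in order against compound 2, which sits at the same limit. Only compound 1, with 62.2 ug/mL, shows that a compound of the shared core can register a numerical value in this assay.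

Compound 4 `CC(C)(C)n1ncc(OCc2nnc(-c3ccccc3F)o2)c(Cl)c1=O` differs from compound 3 by 2-fluorophenyl in place of thiophen-2-yl on an aromatic carbon. Among the measured compounds shown here, no step between measured compounds is available to calibrate this change, and the two limits give no direction. Because compound 3 sits at the limit of > 300 ug/mL in this assay, at which 2 of the 3 values shown sit, the step from compound 3 to compound 4 is expected to be an at least 1.5-fold lower number from compound 3 to compound 4 (0.17 log units; that floor lies within the scatter), with a real chance that compound 4 again returns only a limit. The estimate for compound 4 in this assay is 200 ug/mL, within a range from 60 ug/mL to 300 ug/mL.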

Compound 4, half-maximal effective concentration: 16.8 ug/mL
The estimate for compound 4 lay 12-fold (1.08 log units) above the measured number, outside the stated range (below it).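

In this assay, putting 2-fluorophenyl in place of thiophen-2-yl on this aromatic carbon gives an at least 17-fold lower number from compound 3 to compound 4 (1.25 log units; beyond the scatter), and the result moves from a limit to a measured number. Among the compounds shown here, this is the first comparison here between compounds that differ in one place, and it shows that the group at this position alone can decide whether the shared core registers a number in this assay. The step can be read only as a lower bound on the change because the result for compound 3 is a limit and not a number: the limit of > 300 ug/mL in this assay, at which 2 of the 4 values shown sit.

Going by these compounds, it remains open whether the fluorine or the six-membered aromatic ring of carbon carries the step, and how a plain phenyl, a methoxy group or an amine would fare at this position. On these data alone, whether the same change would have a similar effect on another core also remains unknown.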